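Dropping the methoxy group from compound 3

The source may hold more compounds than are shown below. What is called first, only, known or untested is meant among the compounds shown, and "the series" means these compounds.

Measured so far:
- compound 1, `Cc1ccc(-c2nn(-c3ccccc3)cc2C(=O)NC(=S)Nc2ccc(Cl)cc2)cc1`, 3170 nM
- compound 2, `Cc1ccc(NC(=S)NC(=O)c2cn(-c3ccccc3)nc2-c2ccccc2)cc1`, 2800 nM
- compound 3, `COc1ccc(-c2nn(-c3ccccc3)cc2C(=O)NC(=S)Nc2ccc(Cl)cc2)cc1`, 1310 nM

All three were tested in a functional assay on A549 cells (Homo sapiens) for inhibition, read by CCK-8 assay, with a stated time of 48 h; a higher number here means a weaker inhibitor, a lower number a stronger inhibitor. Compound 3 gives the lowest number of the three: compound 2 sits a step above it, and compound 1 sits further above it. Among the compounds with values here, the one direct comparison within these data is the change from compound 1 to compound 3, which is a 2.4-fold lower number from compound 1 to compound 3 (0.38 log units; beyond the scatter).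

Compound 4, `O=C(NC(=S)Nc1ccc(Cl)cc1)c1cn(-c2ccccc2)nc1-c1ccccc1`, has not yet been measured. It differs from compound 3 in one place: hydrogen in place of methoxy on an aromatic carbon. Within the data shown here, no measured step covers exactly this change. The closest hint is compound 2, which also carries a plain phenyl at that position but a different group on the other ring, and which gives 2800 nM. Since the methoxy of compound 3 went with the lowest number here, removing it is expected to push the number upward, by a 1.9-fold higher number from compound 3 to compound 4 (0.28 log units; within the scatter). Compound 4 is therefore estimated at 2500 nM, with a plausible range from 1000 nM to 6500 nM.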

Compound 4, half-maximal inhibitory concentration: 3200 nM
For compound 4 the middle estimate is 1.3-fold (0.11 log units) below the measured one, and the stated range covers the measured number.
By their numbers in this assay, from the lowest: compound 3; then compounds 2, 1 and 4 (each within the scatter of the next).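

In this assay, within the data shown here, removing the methoxy gives a 2.4-fold higher number from compound 3 to compound 4 (0.39 log units; beyond the scatter) and so undoes the earlier gain, while a 1.0-fold higher number from compound 1 to compound 4 (0.00 log units; within the scatter) shows that hydrogen and methyl cannot be told apart at this position, leaving methoxy as the only one of the three groups here that stands out. With the plain phenyl in place, a 1.1-fold higher number from compound 2 to compound 4 (0.06 log units; within the scatter) shows that exchanging methyl for chloro on the other ring also makes no difference beyond the scatter. No measurement given here explains why methoxy stands apart.

As far as these compounds go, whether a hydroxyl, an amine or a longer chain such as ethoxy at this position would match methoxy remains open. From the compounds shown here alone, it is also open whether methoxy would have the same effect with methyl in place of chloro on the other ring.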